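Trimming one methoxy from the trimethoxyphenyl chalcone

This account rests on a few compounds, and the source may have more. Where it says the series, first, only, none or still open, it means among the compounds named here.

Compound 1 `COc1ccc(-c2cc(/C=C/C(=O)c3ccc(N)cc3)[nH]n2)cc1` gives -6% in a functional assay on OVCAR-4 cells (Homo sapiens) for cytotoxicity, read by sulforhodamine B assay, with a stated time of 48 h, tested at 10 uM; a lower number here means a stronger effect, a higher number a weaker effect of the compound at the concentration tested.
Compound 2 `COc1cc(-c2cc(/C=C/C(=O)c3ccc(N)cc3)[nH]n2)cc(OC)c1OC` gives -22% in this assay.
Compound 3 `COc1ccc(C(=O)/C=C/c2cc(-c3cc(OC)c(OC)c(OC)c3)n[nH]2)cc1` gives -7% in this assay.

Compound 2 stands lowest of the three numbers; compound 3 and compound 1 both lie higher, beyond the scatter. Among the measured compounds shown here, the only measured step, a number 15 percentage points higher from compound 2 to compound 3 (beyond the scatter), concerns the amino end and not the methoxy groups, so it does not bear on the change to compound 4 `COc1ccc(-c2cc(/C=C/C(=O)c3ccc(N)cc3)[nH]n2)cc1OC`. That change is hydrogen in place of methoxy on an aromatic carbon. Compound 1, carrying a single methoxy group, shows a higher number than compound 2 with three, which hints that fewer methoxy groups weaken the effect. A modest upward step a number 8 percentage points higher from compound 2 to compound 4 (within the scatter) is therefore expected, and compound 4 is estimated at -14%, within -30% to 2%.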

Compound 4, a percentage reported as activity, at one concentration (the size of the read-out at that concentration, not a potency): 24%
For compound 4 the middle estimate is 38 percentage points below the measured one; the measured number lies above the stated range.
By their numbers in this assay, from the lowest: compound 2; then compounds 3 and 1 (each within the scatter of the next); then compound 4.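

In this assay, taking a methoxy group away gives a number 46 percentage points higher from compound 2 to compound 4 (beyond the scatter), yet putting a methoxy group onto the ring of compound 1 gives a number 30 percentage points higher from compound 1 to compound 4 (beyond the scatter). Removing and adding a methoxy group thus both move the number the same way, with compound 4 as the end point of each step. Among these compounds, the outcome of this change depends on which other methoxy groups the ring carries, so simply counting them does not predict the number.

Nothing measured here explains this result. Going by these compounds, whether a hydroxyl group, an ethoxy group or a fluorine atom at this position would behave like methoxy or like hydrogen remains open.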